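The compounds below may be only part of what the source reports. "The series", "measured", "known", "first", "only" and "open" are said of these compounds alone.

Measured compounds:
compound 1 `CCCCCCCOc1cc(CCc2nc(C)c(CC)s2)nc(NCc2cc(Cl)cc(NC(=O)OC(C)C)c2)c1`: 72 nM
compound 2 `CCc1sc(CCc2cc(OC3CCCCC3)cc(NCc3cc(Cl)cc(NC(=O)OC(C)C)c3)n2)nc1C`: 29 nM
compound 3 `CCc1sc(CCc2cc(OC3CCOCC3)cc(NCc3cc(Cl)cc(NC(=O)OC(C)C)c3)n2)nc1C`: 4.4 nM

All three were run in an assay on cells for binding affinity to Neuropeptide Y receptor type 1 (Homo sapiens); on this read-out lower numbers stand for stronger inhibition and higher numbers for weaker inhibition. Compound 1 gives the highest number of the three. Its nearest neighbour is compound 2, with a 2.5-fold lower number from compound 1 to compound 2 (0.39 log units; beyond the scatter); the furthest is compound 3, with a 16-fold lower number from compound 1 to compound 3 (1.21 log units; beyond the scatter). Between the two ring-bearing compounds the gap is a 6.6-fold lower number from compound 2 to compound 3 (0.82 log units; beyond the scatter).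

Compound 4 `CCc1sc(CCc2cc(OCCc3ccccc3)cc(NCc3cc(Cl)cc(NC(=O)OC(C)C)c3)n2)nc1C` is not yet measured. It differs from compound 1 in one place: phenyl in place of pentyl on a saturated chain carbon, two bonds along the chain from an oxygen on an aromatic ring. The two measured steps from compound 1 both replace the heptyl on the ring oxygen with a ring group and both lower the number, the oxan-4-yl step far more than the cyclohexyl step. For the measured compounds named here, compound 4 instead keeps a chain on the oxygen and ends it in phenyl; none of the measured compounds carries such a chain-linked ring, so the cyclohexyl step is taken as the closer guide and the oxan-4-yl step as an upper bound. A modest lowering, a 2.1-fold lower number from compound 1 to compound 4 (0.31 log units; beyond the scatter), is therefore expected in this assay, beyond the scatter but short of the oxan-4-yl result. The estimate for compound 4 is 35 nM, with a range from 12 nM to 100 nM.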

Compound 4, half-maximal inhibitory concentration: 30 nM
For compound 4 the middle estimate is 1.2-fold (0.07 log units) above the measured one; the measured number falls inside the stated range.
By their numbers in this assay, from the lowest: compound 3; then compounds 2 and 4 (each within the scatter of the next); then compound 1.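

Phenyl in place of pentyl on the chain lowers the number in this assay (a 2.4-fold lower number from compound 1 to compound 4 (0.38 log units; beyond the scatter)), so at this position a group need not be a ring attached to the oxygen for the number to fall below that of the heptyl compound. Phenethyl and cyclohexyl are not separated (a 1.0-fold higher number from compound 2 to compound 4 (0.01 log units; within the scatter)), while phenethyl stays well apart from oxan-4-yl (a 6.8-fold higher number from compound 3 to compound 4 (0.83 log units; beyond the scatter)), which leaves compound 3 alone at the low end of the four. Nothing on hand accounts for these differences.

Still open, as far as these compounds go, is how the number responds to the length of the chain ending in phenyl, as with benzyl or 3-phenylpropyl. Also open, from the compounds shown here alone, is whether piperidin-4-yl or a pyridine ring at the end of the chain would behave like oxan-4-yl or like phenethyl.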